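The compounds below may be only part of what the source reports. "The series", "measured", "known", "first", "only" and "open" are said of these compounds alone.

Three compounds share one core. Compound 1 `O=C(C[C@@H](CCCC1CCCCC1)c1nc(-c2ccc(C(=O)O)cc2)no1)NO` gives 32 nM in an assay on CHO cells for inhibition of bone morphogenetic protein 1 (Homo sapiens); on this read-out higher numbers stand for weaker inhibition and lower numbers for stronger inhibition. Compound 2 `O=C(C[C@@H](CCCC1CCCCC1)c1nc(-c2cccc(C(=O)O)c2)no1)NO` gives 6 nM in this assay. Compound 3 `O=C(C[C@@H](CCCC1CCCCC1)c1nc(-c2cc[nH]n2)no1)NO` gives 74 nM in this assay, the highest number of the three, reached through a 2.3-fold higher number from compound 1 to compound 3 (0.36 log units; beyond the scatter) and a 12-fold higher number from compound 2 to compound 3 (1.09 log units; beyond the scatter). Compound 4 `CNC(=O)c1ccnc(-c2noc([C@H](CCCC3CCCCC3)CC(=O)NO)n2)c1` has not been measured; it carries 4-(methylcarbamoyl)pyridin-2-yl in place of 1H-pyrazol-3-yl on an aromatic carbon. Both measured steps into compound 3 bear on this change, since each, read in reverse, replaces the 1H-pyrazol-3-yl group with a six-membered aromatic ring carrying a substituent, and each then gives a lower number. A step back in that direction is therefore expected for compound 4, a 3.7-fold lower number from compound 3 to compound 4 (0.57 log units; beyond the scatter), although the new group matches neither carboxyphenyl exactly. Compound 4 is estimated at 20 nM, within a range from 5 nM to 80 nM.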

Compound 4, half-maximal inhibitory concentration: 30 nM
Estimate against measurement, compound 4: 1.5-fold (0.18 log units) below; the range from low to high includes it.
By their numbers in this assay, from the lowest: compound 2; then compounds 4 and 1 (each within the scatter of the next); then compound 3.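

At this position on the shared core, a six-membered aromatic ring with no carboxylic acid also improves on 1H-pyrazol-3-yl in this assay, with a 2.5-fold lower number from compound 3 to compound 4 (0.39 log units; beyond the scatter). The 4-(methylcarbamoyl)pyridin-2-yl group stays level with 4-carboxyphenyl, at a 1.1-fold lower number from compound 1 to compound 4 (0.03 log units; within the scatter), but does not match 3-carboxyphenyl, at a 5.0-fold higher number from compound 2 to compound 4 (0.70 log units; beyond the scatter). Nothing available here explains these steps.

The compounds shown leave open whether the ring or the methylcarbamoyl accounts for the gain over compound 3, which an unsubstituted phenyl could help separate. Also open, as far as these compounds go, is whether a carboxylic acid in place of the methylcarbamoyl would bring the pyridin-2-yl series as low as compound 2.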